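The source may hold more compounds than are shown below. What is called first, only, known or untested is meant among the compounds shown, and "the series" means these compounds.

Compound 3 (`Cc1oc2c([C@H]3CCN(C)C[C@H]3O)c(O)cc(O)c2c(=O)c1C(O)c1ccc([N+](=O)[O-])cc1`) gives 0% in a functional assay on HL-60 cells (Homo sapiens) for inhibition, read by MTT assay, with a stated time of 48 h, tested at 10 uM (a lower number here means less inhibition of growth, a higher number more inhibition of growth at the concentration tested), and so stands lowest of the three compounds measured, with compound 1 (`Cc1cc(=O)c2c(O)c(CN3CCN(C(=O)OC(C)(C)C)CC3)c(O)c([C@H]3CCN(C)C[C@H]3O)c2o1`) at 13% and compound 2 (`Cc1cc(=O)c2c(O)c(CN(C)CC(=O)O)c(O)c([C@H]3CCN(C)C[C@H]3O)c2o1`) at 23% on the higher side, both gaps beyond the scatter. Compound 4 (`COc1ccc(C(O)c2c(C)oc3c([C@H]4CCN(C)C[C@H]4O)c(O)cc(O)c3c2=O)cc1Br`) carries 3-bromo-4-methoxyphenyl in place of 4-nitrophenyl on a saturated chain carbon bound to an aromatic carbon and an oxygen on a saturated carbon, a change counted as 3-bromo-4-methoxyphenyl in place of 4-nitrophenyl on a saturated chain carbon bound to an aromatic carbon and an oxygen on a saturated carbon in full. Going by the values given here, no measured pair differs in one place, so the data offer no direct guide to this swap. The expected step of a number 12 percentage points higher from compound 3 to compound 4 (beyond the scatter) is a modest rise, close to the usual scatter, since compound 3 at 0% leaves room only upward. For compound 4 the expected inhibition is 12% (estimated range 0% to 35%).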

Compound 4, percent growth inhibition at one concentration: 23%
For compound 4 the middle estimate is 11 percentage points below the measured one; measured number inside the range.
By their numbers in this assay, from the lowest: compound 3; then compounds 1, 2 and 4 (each within the scatter of the next).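

In this assay, 3-bromo-4-methoxyphenyl in place of 4-nitrophenyl on a saturated chain carbon bound to an aromatic carbon and an oxygen on a saturated carbon gives a number 23 percentage points higher from compound 3 to compound 4 (beyond the scatter). Going by these compounds alone, this is the first single-place comparison, and it shows that growth inhibition at this position changes with the aryl group it carries. Nothing at hand explains the step. The compounds shown leave open whether the bromo or the methoxy group alone accounts for it, and how an amine or a carboxylic acid in place of the aryl group would read.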